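The source may report more compounds than this note shows. Statements on the series, on what has been measured and on what is new or still open speak of the compounds shown alone.

Working notes on the chlorinated fused-core series carrying a chloromethyl-substituted benzyl group.

Compound 1 `ClCc1cccc(Cn2cnc3c(Cl)ncnc32)c1` is tested in a functional assay on NCI-H522 cells (Homo sapiens) for cytotoxicity, read by sulforhodamine B assay, with a stated time of 48 h; on this read-out lower numbers stand for higher toxicity in this test and higher numbers for lower toxicity in this test. In this assay compound 1 sits at the limit of the measurement, > 100000 nM. Compound 2 `ClCc1cccc(Cn2cnc3c(Cl)nc(Cl)nc32)c1` carries one further chloro group; in this assay compound 2 gives 17000 nM. The step is an at least 5.8-fold lower number from compound 1 to compound 2 (0.76 log units; beyond the scatter), produced by the change (chloro in place of hydrogen on an aromatic carbon). The step is stated only as a lower bound because the limit of > 100000 nM in this assay, at which 2 of the 3 values shown sit, holds compound 1.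

Compound 3 `ClCc1ccccc1Cn1cnc2ncnc(Cl)c21` has the same atoms as compound 1 joined differently; the difference between the two cores is not broken down here. In this assay compound 3 also sits at the limit, > 100000 nM. Compound 4 `ClCc1ccccc1Cn1cnc2nc(Cl)nc(Cl)c21` differs from compound 3 by chloro in place of hydrogen on an aromatic carbon, the same change as that between compound 1 and compound 2, with matching surroundings.

The expected step is an at least 4.0-fold lower number from compound 3 to compound 4 (0.60 log units; beyond the scatter), resting on the measured step of an at least 5.8-fold lower number from compound 1 to compound 2 (0.76 log units; beyond the scatter) and on the fact that the limit of > 100000 nM in this assay, at which 2 of the 3 values shown sit, also holds compound 3, so that the starting point is itself unknown. For compound 4 in this assay the estimate is 25000 nM, with a range from 8000 nM to 100000 nM.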

Compound 4, concentration lethal to 50% of the cells: > 100000 nM
Compound 4 ended at the assay's limit (the forecaster's own chance of this, stated with the estimate: 35%); middle value at least 4.0-fold (0.60 log units) from the limit.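

No step can be read from compound 3 to compound 4 in this assay, because both compounds sit at the limit of the measurement: the limit of > 100000 nM in this assay, at which 3 of the 4 values shown sit.

The compounds shown leave open whether the chloro change that gave a readable step between compound 1 and compound 2 has any effect on the read-out with compound 3.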